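This account rests on a few compounds, and the source may have more. Where it says the series, first, only, none or still open, it means among the compounds named here.

Three compounds share one core and differ only in the group attached to it. Compound 1 `CC(C)c1nc(N)c2nn(-c3ccccc3)cc2n1` carries isopropyl and gives 11% in an assay on CHO cells for displacement of a labelled ligand from adenosine receptor A3 (Homo sapiens), read by scintillation counting, tested at 1 uM; on this read-out lower numbers stand for less inhibition and higher numbers for more inhibition at the one concentration tested (going by the name of the read-out). Compound 2 `COc1ccc(Cc2nc(N)c3nn(-c4ccccc4)cc3n2)cc1` carries a 4-methoxybenzyl group and gives 38%. Compound 3 `Cc1cccc(Cc2nc(N)c3nn(-c4ccccc4)cc3n2)c1` carries a 3-methylbenzyl group and gives 11%. On these numbers compound 3 stands level with compound 1, the two together at the bottom of the three; the exchange recorded as no change at the digits printed from compound 1 to compound 3 (within the scatter) shows this, while a number 27 percentage points lower from compound 2 to compound 3 (beyond the scatter) shows that the pattern of the benzyl group can move the read-out by a modest amount.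

Compound 4 `Cc1ccc(Cc2nc(N)c3nn(-c4ccccc4)cc3n2)cc1` differs from compound 3 as follows: 4-methylphenyl in place of 3-methylphenyl on a saturated chain carbon bound to an aromatic carbon. Among the compounds with values here, no measured step tests exactly this change. Within the data shown here, the only bearing step is the one between compound 2 and compound 3, whose size suggests that reshuffling the substituent on the benzyl ring may matter, yet methyl and methoxy are not the same group. A small rise is therefore expected for compound 4, as a number 9 percentage points higher from compound 3 to compound 4 (within the scatter), giving an estimated 20% with a range from 5% to 40%.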

Compound 4, a percentage reported as inhibition, at one concentration (the size of the read-out at that concentration, not a potency): 39%
Estimate against measurement, compound 4: 19 percentage points below; low and high end bracket the measured number.
By their numbers in this assay, from the lowest: compounds 1 and 3 (each within the scatter of the next); then compounds 2 and 4 (each within the scatter of the next).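

Exchanging 3-methylbenzyl for 4-methylbenzyl in this assay gives a number 28 percentage points higher from compound 3 to compound 4 (beyond the scatter) with the same atoms joined differently, so where the single methyl sits on the benzyl ring can alone move this read-out. Methyl in place of methoxy gives a number 1 percentage points higher from compound 2 to compound 4 (within the scatter) and 4-methylbenzyl in place of isopropyl gives a number 28 percentage points higher from compound 1 to compound 4 (beyond the scatter) while 3-methylbenzyl does not clear isopropyl, so among these compounds a benzyl group alone is not enough and only the two groups named with a 4 stand clear of it. Nothing measured here explains the difference between the two methyl placements. As far as these compounds go, whether an amine or a carboxylic acid in place of the methyl of compound 4 would hold the number stays open. So does the effect of a longer chain in place of the saturated chain carbon.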